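Compound 3 to compound 4: hydroxymethyl for dimethylamino

This account rests on a few compounds, and the source may have more. Where it says the series, first, only, none or still open, it means among the compounds named here.

Measured in an ADME assay on Raji cells (Homo sapiens) for cytotoxicity, read by luminescence, with a stated time of 72 h; on this read-out lower numbers stand for an effect already at smaller amounts and higher numbers for an effect only at larger amounts of compound (each value a limit):
compound 1 `CCCOc1cccc(-c2[nH]c3cc(OC)ccc3c(=O)c2C(=O)OCC)c1`: > 21500 nM
compound 2 `CCOC(=O)c1c(-c2cccc(OC(C)C)c2)[nH]c2cc(OC)ccc2c1=O`: > 21500 nM
compound 3 `CCOC(=O)c1c(-c2cccc(N(C)C)c2)[nH]c2cc(OC)ccc2c1=O`: > 21500 nM

Compound 3 gives > 21500 nM as a limit and not as a number. It holds no rank within the series, since all three compounds sit at the same limit (the limit of > 21500 nM in this assay, at which 3 of the 3 values shown sit). Compound 4 `CCOC(=O)c1c(-c2cccc(CO)c2)[nH]c2cc(OC)ccc2c1=O` has not yet been measured.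

The change from compound 3 to compound 4 is hydroxymethyl in place of dimethylamino on an aromatic carbon and reads as hydroxymethyl in place of dimethylamino on an aromatic carbon, meta to a large group. The nearest measured comparisons are a step that the two limits leave unreadable from compound 1 to compound 3 and a step that the two limits leave unreadable from compound 2 to compound 3 at this same aromatic carbon. The third comparison is a step that the two limits leave unreadable from compound 1 to compound 2 and it gives no size either. Within the data shown here, no measured step therefore supplies a size or direction to carry over, and hydroxymethyl appears on no measured compound.

The working expectation is that the series stays at its limit. What is expected is a step that the limit leaves unreadable from compound 3 to compound 4 with no direction that the measured steps could support. Compound 4 is estimated at 25000 nM with an expected range of 9000 nM to 60000 nM in this assay and a further reading at the limit is the likeliest result.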

Compound 4, half-maximal effective concentration: > 21500 nM
Compound 4: no number, only a limit; the forecaster's own chance of this, stated with the estimate: 80%; the middle value lies beyond the limit too.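

In this assay compound 4 gives > 21500 nM, a limit and not a number. Its steps from compound 1, compound 2 and compound 3 therefore cannot be read, and the series holds a single reading: the limit of > 21500 nM in this assay, at which 4 of the 4 values shown sit.

The compounds shown leave open whether any change at this aromatic carbon, or elsewhere on the shared core, would give a measurable value in this assay.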